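Restoring an Aryl Ring on the Cyclopropane

This account rests on a few compounds, and the source may have more. Where it says the series, first, only, none or still open, it means among the compounds named here.

Compound 1 `CC[C@H](C)[C@H](N)CN(C(=O)[C@@H]1C[C@H]1c1ccc(F)cc1)c1ccc(-c2ccccc2)cc1` gives 600 nM in a functional assay for agonist activity at G protein-coupled receptor 88 (Homo sapiens), read by HTRF and cAMP accumulation; a higher number here means that more compound is needed for the effect, a lower number that less compound is needed. Compound 2 `CC[C@H](C)[C@H](N)CN(C(=O)[C@@H]1C[C@H]1c1cccc(F)c1)c1ccc(-c2ccccc2)cc1` gives 560 nM in this assay, and a 1.1-fold lower number from compound 1 to compound 2 (0.03 log units; within the scatter). Compound 3 `CC[C@H](C)[C@H](N)CN(C(=O)[C@@H]1C[C@H]1C1CCCCC1)c1ccc(-c2ccccc2)cc1` reaches only a limit of this assay, > 25000 nM; this is the limit of > 25000 nM in this assay, at which 1 of the 3 values shown sits. Compound 3 thus stands as the weakest of the three, since an at least 41-fold higher number from compound 1 to compound 3 (1.61 log units; beyond the scatter) and an at least 44-fold higher number from compound 2 to compound 3 (1.64 log units; beyond the scatter). Compound 4 `CC[C@H](C)[C@H](N)CN(C(=O)[C@@H]1C[C@H]1c1ccc(F)c(F)c1)c1ccc(-c2ccccc2)cc1` differs from compound 3 in that (3,4-difluorophenyl in place of cyclohexyl on a saturated ring carbon). Because an at least 41-fold higher number from compound 1 to compound 3 (1.61 log units; beyond the scatter) and an at least 44-fold higher number from compound 2 to compound 3 (1.64 log units; beyond the scatter) both turn on this same ring, compound 4 is expected to show an at least 50-fold lower number from compound 3 to compound 4 (1.69 log units; beyond the scatter). Compound 4 is therefore estimated to give about 500 nM in this assay, within a range from 150 nM to 2500 nM.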

Compound 4, half-maximal effective concentration: 720 nM
Beside the measured number, compound 4's estimate is 1.4-fold (0.16 log units) below it; measured number inside the range.
By their numbers in this assay, from the lowest: compounds 2, 1 and 4 (each within the scatter of the next). At a limit, above all of these: compound 3.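

Replacing cyclohexyl with 3,4-difluorophenyl on the cyclopropane carbon gives an at least 34-fold lower number from compound 3 to compound 4 (1.54 log units; beyond the scatter) in this assay. Compound 3 stands at a limit, so that step is only a bound: the limit of > 25000 nM in this assay, at which 1 of the 4 values shown sits.
Adding fluoro in place of hydrogen on the aromatic ring gives a 1.3-fold higher number from compound 2 to compound 4 (0.11 log units; within the scatter) and a 1.2-fold higher number from compound 1 to compound 4 (0.08 log units; within the scatter), so among these compounds the aromatic ring counts for more than how many fluoro groups it carries.

From the compounds shown here alone, it remains open whether an unsubstituted phenyl, or a phenyl bearing methoxy or a nitrile, would stay at this level. Also open, going by these compounds, is whether a saturated ring smaller than cyclohexyl, such as cyclopentyl, would behave like compound 3.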